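The compounds below may be only part of what the source reports. "The series", "measured", "known", "first", "only" and "open" are said of these compounds alone.

Measured compounds:
- compound 1, `CCC[C@@H](OC(C)=O)C1=C(Br)C(=C(Br)Br)OC1=O`, gives < 0.1 ug/mL in a functional assay on ZR-75-1 cells (Homo sapiens) for cytotoxicity; a lower number here means that less compound is needed, a higher number that more compound is needed for the effect; this value is a limit of the assay, not a number.
- compound 2, `CCC[C@@H](O)C1=C(Br)C(=C(Br)Br)OC1=O`, gives 0.3 ug/mL in this assay.
- compound 3, `CCC[C@@H](O)C1=C(Br)/C(=C/I)OC1=O`, gives 0.3 ug/mL in this assay.

Compound 1 and compound 2 share a core and differ in one place: acetyl in place of hydrogen on an oxygen on a saturated carbon. This change brings an at least 3.0-fold lower number from compound 2 to compound 1 (0.47 log units; beyond the scatter), where the value of compound 1 is a limit, so the true size of the step is open at the lower end; the limit is the limit of < 0.1 ug/mL in this assay, at which 1 of the 3 values shown sits. Compound 3 stands level with compound 2 at the digits given, within the scatter. The difference between the core of compound 3 and the core of compound 2 is not broken down here.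

Compound 4, `CCC[C@@H](OC(C)=O)C1=C(Br)/C(=C/I)OC1=O`, has not yet been measured in this assay. It differs from compound 3 by acetyl in place of hydrogen on an oxygen on a saturated carbon, the same kind of change as from compound 2 to compound 1, at a place described in the same words. Because compound 3 sits at 0.3 ug/mL and the earlier change gave an at least 3.0-fold lower number from compound 2 to compound 1 (0.47 log units; beyond the scatter), compound 4 is expected to show a 3.0-fold lower number from compound 3 to compound 4 (0.48 log units; beyond the scatter). The estimate for compound 4 in this assay is 0.1 ug/mL, between 0.03 ug/mL and 0.3 ug/mL, with a fair chance that only a limit is reported.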

Compound 4, concentration for half-maximal effect: < 0.1 ug/mL
Compound 4: a limit, no number; the forecaster's own chance of this, stated with the estimate: 50%; the middle value sits exactly at the limit.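

Putting acetyl in place of hydrogen on the oxygen on a saturated carbon brings an at least 3.0-fold lower number from compound 3 to compound 4 (0.47 log units; beyond the scatter) in this assay. The value of compound 4 is a limit of the assay, not a number: the limit of < 0.1 ug/mL in this assay, at which 2 of the 4 values shown sit.

The change therefore points the same way on both cores shown and lies beyond the scatter on each, but this rests on two cores only, and it does not show that the size of the step carries over: the same change on two cores in this assay, an at least 3.0-fold lower number (0.47 log units; beyond the scatter) from compound 2 to compound 1 and an at least 3.0-fold lower number (0.47 log units; beyond the scatter) from compound 3 to compound 4; the limit leaves it open whether they differ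

The compounds shown leave open whether a benzoyl group or a methyl ether on the same oxygen would bring a step like that of the acetyl group, and how far the acetoxy compounds reach past the limit of the assay. They also leave open whether the change would hold with a longer chain on the saturated carbon, or with an amine or a carboxylic acid at the end of that chain.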